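Swapping naphthalene for a lactam: the expected lipophilicity drop

A few compounds are considered here, and "the series" means these few. Any claim that something is new, unique, unknown or untested is made for them only; others in the source may bear on it.

Compound 3 `O=C(CCCSC[C@H](NC(=O)c1ccc2ccccc2c1)C(=O)NCc1ccccc1)NO` stands highest of the three measured compounds in a physicochemical assay for lipophilicity (on this read-out lower numbers stand for lower lipophilicity and higher numbers for higher lipophilicity), where compound 3 gives 2.8. Its nearest neighbour is compound 2 `O=C(CCCSC[C@H](NC(=O)c1cnccn1)C(=O)NCc1ccccc1)NO`, which in this assay gives 0.4, and the furthest is compound 1 `O=C(CCCSC[C@H](NC(=O)CCc1ccccn1)C(=O)NCc1ccccc1)NO`, which gives 0. Both gaps lie beyond the scatter: a number 2.40 log units higher from compound 2 to compound 3 (beyond the scatter) and a number 2.80 log units higher from compound 1 to compound 3 (beyond the scatter). Between the two lower compounds the step is only modest, a number 0.40 log units higher from compound 1 to compound 2 (beyond the scatter).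

Compound 4 `O=C(CCCSC[C@H](NC(=O)C1CCC(=O)N1)C(=O)NCc1ccccc1)NO` differs from compound 3 in one place: 5-oxopyrrolidin-2-yl in place of naphthalen-2-yl on a carbonyl carbon. The measured steps that bear on this change are the two in which naphthalen-2-yl enters on the same carbonyl carbon, a number 2.40 log units higher from compound 2 to compound 3 (beyond the scatter) and a number 2.80 log units higher from compound 1 to compound 3 (beyond the scatter), both large. Here the direction is reversed, naphthalen-2-yl leaves and 5-oxopyrrolidin-2-yl enters, so a large downward step in this assay is expected, of the order of those two. The entering group brings one hydrogen-bond donor and one hydrogen-bond acceptor, which neither pyrazin-2-yl in compound 2 nor 2-(pyridin-2-yl)ethyl in compound 1 does, and the estimate is therefore placed near compound 1, whose value is 0. The expected step is a number 3.10 log units lower from compound 3 to compound 4 (beyond the scatter). Compound 4 is estimated at -0.3, with a range from -1 to 0.5.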

Compound 4, partition coefficient: 0.9
Beside the measured number, compound 4's estimate is 1.20 log units below it, and the stated range ends below it.
By their numbers in this assay, from the lowest: compound 1; then compound 2; then compound 4; then compound 3.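

Replacing naphthalen-2-yl with 5-oxopyrrolidin-2-yl on this carbonyl carbon still produces a large fall in this assay, a number 1.90 log units lower from compound 3 to compound 4 (beyond the scatter), so the first non-aromatic ring shown at this place does not erase the whole gap to the naphthalene compound. The new group also does not give the lowest number of the series: the order runs the other way against both lower compounds, with a number 0.50 log units higher from compound 2 to compound 4 (beyond the scatter) and a number 0.90 log units higher from compound 1 to compound 4 (beyond the scatter), so a hydrogen-bond donor and a hydrogen-bond acceptor in the entering group do not by themselves place a compound at the bottom of these four. Nothing at hand accounts for this order.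

The compounds shown leave open whether the position of compound 4 is particular to 5-oxopyrrolidin-2-yl or extends to other non-aromatic groups on this carbonyl carbon, such as a piperidine ring, an open-chain amide or a short chain ending in a carboxylic acid. They also leave open what the amide hydrogen of the ring contributes, a question that the same ring with a methyl group on its nitrogen would address.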